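The compounds below may be only part of what the source reports. "The series", "measured", "known", "first", "only" and "open" are said of these compounds alone.

Compound 3 `O=C(Nc1nc2ccc(NC(=O)C3CCCO3)cc2s1)C1CCCCC1` gives 1.3 ug/mL in a functional assay on WI-38 VA13 cells (Homo sapiens) for cytotoxicity; on this read-out lower numbers stand for an effect already at smaller amounts and higher numbers for an effect only at larger amounts of compound. Among the numbers obtained, compound 3 stands highest: compound 1 `O=C(Nc1ccc2nc(NC(=O)C3CCCCC3)sc2c1)c1ccccc1F` gives 0.14 ug/mL, and the gap is a 9.3-fold higher number from compound 1 to compound 3 (0.97 log units; beyond the scatter). Compound 2 `O=C(Nc1ccc2nc(NC(=O)C3CCCCC3)sc2c1)c1ccc(Cl)cc1Cl` reaches only a limit of the assay, > 4 ug/mL, in this assay. Compound 4 `CC(C)COC(=O)Nc1ccc2nc(NC(=O)C3CCCCC3)sc2c1` differs from compound 3 by isobutoxy in place of oxolan-2-yl on a carbonyl carbon. Among the compounds with values here, no measured step exchanges a ring for an alkoxy group at this carbonyl carbon; the steps seen there were an at least 28-fold higher number from compound 1 to compound 2 (1.45 log units; beyond the scatter), a 9.3-fold higher number from compound 1 to compound 3 (0.97 log units; beyond the scatter) and an at least 3.0-fold lower number from compound 2 to compound 3 (0.48 log units; beyond the scatter), so exchanges at this position have moved the number by modest to large amounts. Given that, compound 4 is expected to shift by a 1.2-fold higher number from compound 3 to compound 4 (0.09 log units; within the scatter), a step near the scatter. Compound 4 is therefore estimated at 1.6 ug/mL, between 0.4 ug/mL and 5 ug/mL.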

Compound 4, half-maximal effective concentration: 0.72 ug/mL
For compound 4 the middle estimate is 2.2-fold (0.35 log units) above the measured one; the range from low to high includes it.
By their numbers in this assay, from the lowest: compound 1; then compounds 4 and 3 (each within the scatter of the next). At a limit, above all of these: compound 2.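

In this assay, opening the ring of oxolan-2-yl to isobutoxy gives a 1.8-fold lower number from compound 3 to compound 4 (0.26 log units; within the scatter), so at this carbonyl carbon the ring makes no difference beyond the scatter. Isobutoxy stands apart from both aromatic groups, with a 5.1-fold higher number from compound 1 to compound 4 (0.71 log units; beyond the scatter) and an at least 5.5-fold lower number from compound 2 to compound 4 (0.74 log units; beyond the scatter), and those two groups fall on opposite sides of it. Compound 2 stands only at a limit: the limit of > 4 ug/mL in this assay, at which 1 of the 4 values shown sits.

On these data alone, what remains open is whether an amine, a carboxylic acid or a chain longer than isobutoxy at this carbonyl carbon would hold the number in this range. As far as these compounds go, how much of the effect of 2-fluorophenyl depends on its fluorine also stays open.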